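A few compounds are considered here, and "the series" means these few. Any claim that something is new, unique, unknown or untested is made for them only; others in the source may bear on it.

Measured in a functional assay on RXF 393 cells (Homo sapiens) for inhibition, read by sulforhodamine B assay, with a stated time of 48 h; a higher number here means a weaker inhibitor of growth, a lower number a stronger inhibitor of growth:
- compound 1 `Nc1cc(N)c2nc(-c3ccccc3)c(Oc3ccc(Cl)c(Cl)c3)nc2c1` gives 6030 nM
- compound 2 `Nc1cc(N)c2nc(-c3ccccc3)c(NCc3ccc(Cl)c(Cl)c3)nc2c1` gives 3090 nM
- compound 3 `CCOC(=O)[C@H](CCC(=O)O)NC(=O)c1ccc(Sc2nc3cc(N)cc(N)c3nc2-c2ccccc2)cc1` gives 20000 nM

Compound 2 has the lowest number of the three in this assay. The number of compound 1 lies within the scatter of it, so no order between compound 2 and compound 1 can be read. The number of compound 3 lies beyond the scatter, so compound 3 is the weaker inhibitor of the pair.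

Compound 4 `COc1ccc(CNc2nc3cc(N)cc(N)c3nc2-c2ccccc2)cc1` differs from compound 2 in one place: 4-methoxyphenyl in place of 3,4-dichlorophenyl on a saturated chain carbon bound to a nitrogen on an aromatic ring. Among the compounds with values here, no step between two measured compounds isolates this kind of exchange, so the direction rests on the change itself rather than on a measured precedent. In this assay a step toward a higher number is expected, of a size that may reach beyond the scatter but is not expected to be large.

Compound 4 is expected to give 6500 nM in this assay, with a range from 2000 nM to 20000 nM. The estimated step of a 2.1-fold higher number from compound 2 to compound 4 (0.32 log units; beyond the scatter) is expected to run toward weaker growth inhibition.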

Compound 4, concentration for 50% growth inhibition: 5370 nM
Compound 4: middle estimate off by 1.2-fold (0.08 log units), on the high side; the range from low to high includes it.
By their numbers in this assay, from the lowest: compounds 2, 4 and 1 (each within the scatter of the next); then compound 3.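

In this assay the exchange of 3,4-dichlorophenyl for 4-methoxyphenyl gives a 1.7-fold higher number from compound 2 to compound 4 (0.24 log units; within the scatter) and stays within the scatter, so no order between the two compounds can be read. Within the data shown here, this is the first step that isolates a change on this ring, and at this place on a saturated chain carbon bound to a nitrogen on an aromatic ring, the two groups cannot be told apart in this read-out. No supporting measurement bears on this result.

Going by these compounds, whether a single chlorine, an unsubstituted phenyl or a phenyl carrying an amine or a carboxylic acid at this place would move the number beyond the scatter remains open. Also open, on these data alone, is whether this insensitivity holds in any other cell line, since this one pair rests on a single assay.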